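Swapping pyrimidine for pyridine on the benzyl arm

The compounds below may be only part of what the source reports. "The series", "measured", "known", "first", "only" and "open" are said of these compounds alone.

Among the measured compounds shown here, compound 1 `O=C1C(=O)N(Cc2ccc(-c3cncnc3)cc2)c2ccc(OC(F)(F)F)cc21` is the only member of this set with a measured number: in a functional assay on CHO cells for positive allosteric modulation of muscarinic acetylcholine receptor M5 (Homo sapiens), read by FLIPR and calcium flux, with a stated time of 1 h (a lower number here means that less compound is needed, a higher number that more compound is needed for the effect), compound 1 gives 2100 nM. Compound 2 `O=C1C(=O)N(Cc2cccc(Oc3ccccc3)c2)c2ccc(OC(F)(F)F)cc21` reaches only a limit, > 30000 nM, and so stands at the limit of > 30000 nM in this assay, at which 1 of the 2 values shown sits. Compound 3 `O=C1C(=O)N(Cc2ccc(-c3ccncc3)cc2)c2ccc(OC(F)(F)F)cc21` has not yet been measured. It differs from compound 1 by pyridin-4-yl in place of pyrimidin-5-yl on an aromatic carbon. For the measured compounds named here, no measured pair shows this kind of change, so the expected step of a 1.3-fold lower number from compound 1 to compound 3 (0.12 log units; within the scatter) is small and not beyond the usual scatter. For compound 3 the expected value is 1600 nM, with a range from 500 nM to 5000 nM.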

Compound 3, half-maximal effective concentration: 2800 nM
Estimate against measurement, compound 3: 1.8-fold (0.24 log units) below; low and high end bracket the measured number.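

This pair is the only one shown that differs in one place, and it gives the first direct reading at this position. In this assay, pyridin-4-yl in place of pyrimidin-5-yl gives a 1.3-fold higher number from compound 1 to compound 3 (0.12 log units; within the scatter), so on this aromatic carbon, para to a large group, a ring with 1 hetero atom and a ring with 2 hetero atoms cannot be told apart. Nothing shown gives a cause for this result. Going by these compounds, whether a plain phenyl ring, an amine or a carboxylic acid at this position would shift the number remains open.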